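Ethoxy in Place of Nitro on the Shared Core

This account rests on a few compounds, and the source may have more. Where it says the series, first, only, none or still open, it means among the compounds named here.

Of the compounds shown here, three sharing one core have been measured in an ADME assay on L6 cells (Rattus norvegicus) for cytotoxicity, read by resazurin assay, with a stated time of 72 h; a higher number here means a weaker inhibitor, a lower number a stronger inhibitor. There compound 1 `CCc1ccc(C(=O)NC(=O)c2ccccc2O)cc1` gives 70 ug/mL, compound 2 `Cc1ccc(C(=O)NC(=O)c2ccccc2O)cc1` gives 46 ug/mL and compound 3 `O=C(NC(=O)c1ccccc1O)c1ccc([N+](=O)[O-])cc1` gives 53 ug/mL. Compound 3 cannot be separated from the other two, since its gaps to both lie within the scatter.

The next compound, compound 4 `CCOc1ccc(C(=O)NC(=O)c2ccccc2O)cc1`, carries ethoxy in place of nitro on an aromatic carbon, para to a large group (ethoxy in place of nitro on an aromatic carbon). Among the compounds with values here, no measured compound carries ethoxy, so the guidance is indirect. The closest evidence is a 1.3-fold lower number from compound 1 to compound 3 (0.12 log units; within the scatter), with nitro in place of ethyl, and a 1.2-fold higher number from compound 2 to compound 3 (0.06 log units; within the scatter), with nitro in place of methyl. Even a 1.5-fold lower number from compound 1 to compound 2 (0.18 log units; within the scatter), which removes a methyl from the chain, stays within the scatter. No step beyond the scatter is therefore expected in this assay. The estimated step is a 1.1-fold higher number from compound 3 to compound 4 (0.05 log units; within the scatter). For compound 4 the expected value is 60 ug/mL, with an estimated range of 33 ug/mL to 100 ug/mL.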

Compound 4, half-maximal inhibitory concentration: 17 ug/mL
For compound 4 the middle estimate is 3.5-fold (0.55 log units) above the measured one; measured number outside the range, below it.
By their numbers in this assay, from the lowest: compound 4; then compounds 2, 3 and 1 (each within the scatter of the next).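

In this assay, within the data shown here, ethoxy on this aromatic carbon, para to a large group, gives the first change at this position that lies beyond the scatter (a 3.1-fold lower number from compound 3 to compound 4 (0.49 log units; beyond the scatter)). The same holds against the other two groups (a 2.7-fold lower number from compound 2 to compound 4 (0.43 log units; beyond the scatter); a 4.1-fold lower number from compound 1 to compound 4 (0.61 log units; beyond the scatter)), so compound 4 stands apart from compounds 1, 2 and 3, whose numbers gave no sign that this position could shift the result. No measurement shown accounts for this difference.

The compounds shown leave open whether the lower number belongs to ethoxy alone or extends to methoxy, to a longer chain such as propoxy, or to a hydroxyl or an amine at the same place. They also leave open whether ethoxy would give a similar step elsewhere on that ring.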